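Swapping chloro for bromo on a urea phenol

A few compounds are considered here, and "the series" means these few. Any claim that something is new, unique, unknown or untested is made for them only; others in the source may bear on it.

Measured compounds:
- Compound 1, `O=C(Nc1ccccc1)Nc1ccc([N+](=O)[O-])cc1O`: 18200 nM
- Compound 2, `N#Cc1ccc(NC(=O)Nc2ccccc2Br)c(O)c1Cl`: 4200 nM
- Compound 3, `O=C(Nc1ccccc1)Nc1cccc([N+](=O)[O-])c1O`: 33200 nM

All three were tested in an assay for inhibition of C-X-C chemokine receptor type 1 (Homo sapiens), read by radioligand binding; a higher number here means a weaker inhibitor, a lower number a stronger inhibitor. Compound 2 gives the lowest number of the three, 4200 nM, and is the strongest inhibitor in this set: the nearest value is that of compound 1, and the gap to it lies beyond the scatter, while compound 3 lies furthest away, also beyond the scatter. Compounds 1 and 3 share a nitro-bearing phenol, whereas compound 2 carries a cyano group and a chloro group on its phenol and a bromo group on the other ring.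

The unmeasured compound 4, `N#Cc1ccc(NC(=O)Nc2ccccc2Br)c(O)c1Br`, differs from compound 2 in a single place: bromo in place of chloro on an aromatic carbon. Going by the values given here, no measured pair shows the effect of such a swap, so the expectation rests on its small size. An exchange of one halogen for another of this kind is expected to move the number little, with no direction beyond the scatter. Compound 4 is therefore estimated at 3500 nM, within a range from 1400 nM to 9000 nM, which means an expected step of a 1.2-fold lower number from compound 2 to compound 4 (0.08 log units; within the scatter).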

Compound 4, half-maximal inhibitory concentration: 2600 nM
Estimate against measurement, compound 4: 1.3-fold (0.13 log units) above, and the stated range covers the measured number.
By their numbers in this assay, from the lowest: compounds 4 and 2 (each within the scatter of the next); then compounds 1 and 3 (each within the scatter of the next).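

In this assay, placing bromo instead of chloro on this aromatic carbon, ortho to a cyano group and ortho to a hydroxy group, gives a 1.6-fold lower number from compound 2 to compound 4 (0.21 log units; within the scatter), so the two halogens cannot be told apart at this position. Going by these compounds alone, this is the first pair in the set that differs in one place, and it shows that this one exchange, taken alone, leaves the number within the ordinary spread of repeat measurements. No measurement shown here offers an explanation for this result.

As far as these compounds go, whether fluoro, a methyl group or an amine on the same carbon would keep the number in this region remains open. Also open, from the compounds shown here alone, is how the number would respond if a methoxy group took the place of the hydroxy group or a carboxylic acid took the place of the cyano group.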